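A New Aryl Group Beside an Unreadable Step

A few compounds are considered here, and "the series" means these few. Any claim that something is new, unique, unknown or untested is made for them only; others in the source may bear on it.

In an ADME assay on microsomes from liver (Rattus norvegicus) for metabolic stability (on this read-out lower numbers stand for a shorter-lived compound and higher numbers for a longer-lived compound), compound 2 (`Nc1nc(NCCNc2ncc(-c3ncc[nH]3)c(-c3ccc(F)cc3C(F)(F)F)n2)ccc1[N+](=O)[O-]`) gives > 0.5 h as a limit of the assay and not a number. Compound 1 (`Nc1nc(NCCNc2ncc(-c3ncc[nH]3)c(-c3ccc(F)cc3F)n2)ccc1[N+](=O)[O-]`) gives > 0.5 h as a limit too. The two readings therefore coincide, and the evidence says no more than this: the limit of > 0.5 h in this assay, at which 2 of the 2 values shown sit.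

Compound 3 (`Cc1cc(Cl)ccc1-c1nc(NCCNc2ccc([N+](=O)[O-])c(N)n2)ncc1-c1ncc[nH]1`) differs from compound 2 in a single place (4-chloro-2-methylphenyl in place of 4-fluoro-2-(trifluoromethyl)phenyl on an aromatic carbon) with 4-chloro-2-methylphenyl in place of 4-fluoro-2-(trifluoromethyl)phenyl on an aromatic carbon.

For the measured compounds named here, only one measured step bears on this change. It is a step that the two limits leave unreadable from compound 1 to compound 2 and it puts trifluoromethyl in place of fluoro on an aromatic carbon. No size can be read from it, so it offers no direction for the new change either. The expectation is therefore for no step beyond the scatter, with a number no higher from compound 2 to compound 3 (the limit leaves the size open) as the estimated step. The assay may well report only a limit again. For compound 3 the estimated half-life is 0.5 h with an expected range from 0.2 h to 1 h in a numerical reading.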

Compound 3, half-life: > 0.5 h
Compound 3: only a limit was reported (the forecaster's own chance of this, stated with the estimate: 55%); the middle value sits exactly at the limit.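

In this assay compound 3 gives > 0.5 h as a limit of the assay and not a number. For the compounds shown here, compound 1 and compound 2 also stand at a limit, so no step among compound 1, compound 2 and compound 3 can be read. How long the half-lives of these compounds really are, and whether they differ at all, stays open.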